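The source may report more compounds than this note shows. Statements on the series, on what has been measured and on what is new or still open speak of the compounds shown alone.

Series notes. Among the compounds with values here, compound 1 `COC(=O)CCNC(=O)[C@H]1CC=C(CCC=C(C)C)C[C@@H]1c1ccccc1` is the stronger of the two measured members: in an assay on isolated protein for inhibition of Apoptosis regulator Bcl-2 (Homo sapiens), read by fluorescence polarization, with stated times of 5 min and 10 min (a lower number here means a stronger inhibitor, a higher number a weaker inhibitor), compound 1 gives 3100 nM. Compound 2 `CC(C)=CCCC1=CC[C@H](C(=O)NCCC(=O)O)[C@@H](c2ccccc2)C1` differs from it in one place, and in this assay compound 2 reports only a limit, > 23000 nM. Compound 2 thus stands at the limit of > 23000 nM in this assay, at which 1 of the 2 values shown sits. Within the data shown here, the step of an at least 7.4-fold higher number from compound 1 to compound 2 (0.87 log units; beyond the scatter) is the only measured step in the set and places compound 2 at the weak end of what has been measured. Compound 3 `CC(C)=CCCC1=CC[C@H](C(=O)NO)[C@@H](c2ccccc2)C1` goes further along the same part of the molecule: hydroxy in place of 2-carboxyethyl on an amide-type nitrogen. Among the measured compounds shown here, no measured step covers this change directly; the one measured step, an at least 7.4-fold higher number from compound 1 to compound 2 (0.87 log units; beyond the scatter), shows only that changes at this position move the number beyond the scatter. Compound 3 is therefore expected to remain weak in this assay, with an at least 1.5-fold lower number from compound 2 to compound 3 (0.18 log units; that floor lies within the scatter) uncertain in direction. Compound 3 is estimated at 15000 nM, between 3000 nM and 60000 nM, with a fair chance that only a limit is returned.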

Compound 3, inhibition constant: 600 nM
Estimate against measurement, compound 3: 25-fold (1.40 log units) above; measured number below the stated range.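

Hydroxy in place of 2-carboxyethyl gives an at least 38-fold lower number from compound 2 to compound 3 (1.58 log units; beyond the scatter) and shows that a change on this amide-type nitrogen can lower the number as well as raise it. Hydroxy in place of 2-(methoxycarbonyl)ethyl gives a 5.2-fold lower number from compound 1 to compound 3 (0.71 log units; beyond the scatter) and shows that the longer ester-bearing chain of compound 1 is not required at this position for binding in this assay. The first of these steps is open-ended, as its starting point is a limit for compound 2: the limit of > 23000 nM in this assay, at which 1 of the 3 values shown sits.

Open, on these data alone, is whether the lower number needs the hydroxy on that nitrogen specifically, or whether a methoxy group, a plain amide hydrogen or a 2-hydroxyethyl chain there would serve as well. Also open, as far as these compounds go, is whether compound 3 keeps its number when the phenyl group on the shared core gives way to a pyridyl group.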